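Adding a Second Hydroxy Group to the Phenyl Ring

The source may report more compounds than this note shows. Statements on the series, on what has been measured and on what is new or still open speak of the compounds shown alone.

In a functional assay on MGC-803 cells (Homo sapiens) for cytotoxicity, read by MTT assay, with a stated time of 48 h (a higher number here means a weaker inhibitor, a lower number a stronger inhibitor), compound 2 `Oc1ccccc1/C=N/c1cc2ccccc2nc1-c1ccccc1F` gives 27300 nM, the highest of the two numbers measured, though compound 1 `COc1ccc(/C=N/c2cc3ccccc3nc2-c2ccccc2F)c(O)c1` with 26400 nM lies within the scatter of it. Within the data shown here, the only measured step, a 1.0-fold higher number from compound 1 to compound 2 (0.01 log units; within the scatter), replaced a methoxy group on this ring with hydrogen and changed little. Compound 3 `Oc1cccc(/C=N/c2cc3ccccc3nc2-c2ccccc2F)c1O` differs from compound 2 by hydroxy in place of hydrogen on an aromatic carbon, turning 2-hydroxyphenyl into 2,3-dihydroxyphenyl. Among the measured compounds shown here, with one small change on the same ring as the only guide, no step beyond the scatter is expected. Compound 3 is estimated at 27000 nM, between 12000 nM and 60000 nM. The expected step is a 1.0-fold lower number from compound 2 to compound 3 (0.00 log units; within the scatter).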

Compound 3, half-maximal inhibitory concentration: > 40000 nM
Compound 3 was reported as a limit (the forecaster's own chance of this, stated with the estimate: 10%); at least 1.4-fold (0.17 log units) between middle value and limit.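

The reading for compound 3 is a limit and not a number: the limit of > 40000 nM in this assay, at which 1 of the 3 values shown sits. Putting hydroxy in place of hydrogen at this carbon, ortho to a hydroxy group, gives an at least 1.4-fold higher number from compound 2 to compound 3 (0.16 log units; that floor lies within the scatter), and replacing the whole ring pattern gives an at least 1.5-fold higher number from compound 1 to compound 3 (0.18 log units; that floor lies within the scatter). Unlike the methoxy change, this change therefore shows that the second hydroxy group brings no gain in strength here, although neither floor clears the scatter. As far as these compounds go, how far compound 3 lies past its limit remains open. So does whether an amine or a carboxylic acid at this carbon would behave the same way.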